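This account rests on a few compounds, and the source may have more. Where it says the series, first, only, none or still open, it means among the compounds named here.

Four compounds built on a carbon with a double bond to nitrogen, flanked by two acyl groups, were examined in a functional assay on K562 cells (Homo sapiens) for cytotoxicity, read by MTT assay, with a stated time of 72 h; on this read-out lower numbers stand for higher toxicity in this test and higher numbers for lower toxicity in this test. Compound 1 `CS/C(=N\C(=O)c1ccco1)NC(=O)c1ccco1` carries a methylsulfanyl group on that carbon. In this assay compound 1 reaches only the limit > 100000 nM, a boundary of the test rather than a number. Compound 2 `O=C(/N=C(/NC(=O)c1ccco1)[Se]Cc1ccccc1)c1ccco1` keeps the same core but shows the change (a group of 8 heavy atoms (7 carbon, 1 selenium; one six-membered aromatic ring of carbon only) in place of a group of 2 heavy atoms (1 carbon, 1 sulfur; no ring), on a carbon with a double bond to nitrogen). In this assay compound 2 gives 80600 nM. The step of an at least 1.2-fold lower number from compound 1 to compound 2 (0.09 log units; that floor lies within the scatter) cannot be sized more closely because of the limit of > 100000 nM in this assay, at which 2 of the 3 values shown sit. Compound 3 `CS/C(=N\C(=O)c1cnc2ccccc2c1)NC(=O)c1cnc2ccccc2c1` carries the methylsulfanyl group on another core; the difference between the two cores is not broken down here. In this assay compound 3 reaches only the limit > 100000 nM, again a boundary of the test rather than a number. Compound 4 `O=C(/N=C(/NC(=O)c1cnc2ccccc2c1)[Se]Cc1ccccc1)c1cnc2ccccc2c1` has not yet been measured and differs from compound 3 by a group of 8 heavy atoms (7 carbon, 1 selenium; one six-membered aromatic ring of carbon only) in place of a group of 2 heavy atoms (1 carbon, 1 sulfur; no ring), on a carbon with a double bond to nitrogen, the same change seen earlier. The expected step of an at least 1.3-fold lower number from compound 3 to compound 4 (0.12 log units; that floor lies within the scatter) rests on the measured step of an at least 1.2-fold lower number from compound 1 to compound 2 (0.09 log units; that floor lies within the scatter). In this assay compound 4 is estimated at 75000 nM, within a range from 30000 nM to 150000 nM.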

Compound 4, concentration lethal to 50% of the cells: > 100000 nM
Compound 4 ended at the assay's limit; the forecaster's own chance of this, stated with the estimate: 40%; at least 1.3-fold (0.12 log units) between middle value and limit.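

No new step can be read: in this assay, compound 3 and compound 4 both end at a limit rather than a number, so the change from methylsulfanyl to the selenium-bearing group cannot be sized on this core: the limit of > 100000 nM in this assay, at which 3 of the 4 values shown sit.

The compounds shown leave open whether that change alters the read-out on this core at all.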